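Methoxy for Chloro on a Shared Cinnamoyl Core

The source may hold more compounds than are shown below. What is called first, only, known or untested is meant among the compounds shown, and "the series" means these compounds.

Of the compounds shown here, three built on one core have been measured in a functional assay on HeLa cells (Homo sapiens) for inhibition, read by sulforhodamine B assay, with a stated time of 48 h; on this read-out higher numbers stand for weaker inhibition of growth and lower numbers for stronger inhibition of growth. Compound 1 `O=C(/C=C/c1ccc(Cl)cc1)N1CCC=CS1(=O)=O` gives 26400 nM. In this assay compound 2 `O=C(/C=C/c1c[nH]c2ccc(F)cc12)N1CCC=CS1(=O)=O` gives 18800 nM, and compound 3 `COc1cccc(/C=C/C(=O)N2CCC=CS2(=O)=O)c1` gives 23700 nM. Compound 1 carries the highest of the three numbers, but compound 3 sits nearest to it and compound 2 furthest, and both gaps lie within the usual scatter of repeated measurements, so the three compounds cannot be told apart on these data.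

Compound 4 `COc1ccc(/C=C/C(=O)N2CCC=CS2(=O)=O)cc1` differs from compound 1 by methoxy in place of chloro on an aromatic carbon of a six-membered aromatic ring of carbon only, para to a large group. Going by the values given here, no measured pair shows this exact change, so the size of the step has to be judged from what is available: compound 3, which also carries a methoxy on its ring, gives in this assay a number within the scatter of compound 1. The step of a 1.2-fold lower number from compound 1 to compound 4 (0.08 log units; within the scatter) is therefore expected to be small, with no clear direction beyond the scatter. Compound 4 is estimated at 22000 nM, within a range from 9000 nM to 55000 nM.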

Compound 4, concentration for 50% growth inhibition: 24400 nM
Compound 4: the middle estimate sits 1.1-fold (0.04 log units) below what was measured; the range from low to high includes it.
By their numbers in this assay, from the lowest: compounds 2, 3, 4 and 1 (each within the scatter of the next).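

The earlier compounds shown here offered no pair differing in one place, and compound 4 supplies one, so the exchange of chloro for methoxy on an aromatic carbon, para to a large group, can now be read directly in this assay (a 1.1-fold lower number from compound 1 to compound 4 (0.03 log units; within the scatter)). The step lies within the scatter, so at this position the two groups cannot be told apart on this read-out, even though methoxy brings one more heavy atom and a hydrogen-bond acceptor that chloro lacks. Nothing further is available to explain this outcome.

A single pair with one exchange cannot show whether this position tolerates change in general or whether chloro and methoxy merely happen to give indistinguishable numbers. From the compounds shown here alone, whether an amine, a carboxylic acid or a longer chain such as butoxy at this position would move the number beyond the scatter remains open, as does whether any change on the shared core would do so.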